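Sulfonyl aryl variation in the squalene monooxygenase series

This account rests on a few compounds, and the source may have more. Where it says the series, first, only, none or still open, it means among the compounds named here.

Going by the values given here, compound 2 `CCN(C/C=C/C#CC(C)(C)C)Cc1cccc(OCCN(C)S(=O)(=O)c2cccnc2)c1` gives 150 nM in a functional assay on HepG2 cells for inhibition of squalene monooxygenase (Homo sapiens) (a higher number here means a weaker inhibitor, a lower number a stronger inhibitor), the lowest of the two numbers so far; compound 1 `CCN(C/C=C/C#CC(C)(C)C)Cc1cccc(OCCN(C)S(=O)(=O)c2ccc(F)cc2)c1` gives 255 nM, and the step of a 1.7-fold lower number from compound 1 to compound 2 (0.23 log units; within the scatter) stays within the scatter. Compound 3 `CCN(C/C=C/C#CC(C)(C)C)Cc1cccc(OCCN(C)S(=O)(=O)c2ccc(-c3cccs3)s2)c1` carries the change (5-(thiophen-2-yl)thiophen-2-yl in place of pyridin-3-yl on a sulfonyl sulfur). Among the compounds with values here, the only measured step at this position, a 1.7-fold lower number from compound 1 to compound 2 (0.23 log units; within the scatter), is small, and no step covers the entering group, so no movement beyond the scatter is expected in this assay; the expected step is a 1.1-fold higher number from compound 2 to compound 3 (0.03 log units; within the scatter). Compound 3 is estimated at 160 nM, with a range of 45 nM to 600 nM.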

Compound 3, half-maximal inhibitory concentration: 10000 nM
The estimate for compound 3 lay 63-fold (1.80 log units) below the measured number; the measured number lies above the stated range.
By their numbers in this assay, from the lowest: compounds 2 and 1 (each within the scatter of the next); then compound 3.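

At the sulfonyl sulfur, 5-(thiophen-2-yl)thiophen-2-yl gives a 67-fold higher number from compound 2 to compound 3 (1.82 log units; beyond the scatter) and a 39-fold higher number from compound 1 to compound 3 (1.59 log units; beyond the scatter) in this assay while pyridin-3-yl and 4-fluorophenyl stay within the scatter of each other. The position therefore does not accept every aryl group equally, and the tolerance seen with the two six-membered rings does not reach this two-ring group. Nothing available explains the loss. Open, as far as these compounds go, is whether a single thiophen-2-yl ring would stay near compound 2 or already lose activity, which would show whether the second thiophene ring carries the loss.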